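Series notes: from compound 3 to compound 4

A few compounds are considered here, and "the series" means these few. Any claim that something is new, unique, unknown or untested is made for them only; others in the source may bear on it.

Three compounds sharing one core have numbers in a functional assay on HCT-116 cells (Homo sapiens) for inhibition, read by MTT assay, with a stated time of 48 h; on this read-out higher numbers stand for weaker inhibition and lower numbers for stronger inhibition. Compound 1 `Brc1cccc(CSc2nnc(-c3ccncc3)n2-c2ccccc2)c1` gives 8170 nM in this assay, compound 2 `Clc1ccc(CSc2nnc(-c3ccncc3)n2-c2ccccc2)cc1` gives 10700 nM, and compound 3 `O=C(CSc1nnc(-c2ccncc2)n1-c1ccccc1)N/N=C/c1ccc([N+](=O)[O-])cc1` gives 10200 nM. On these numbers compound 3 has the second highest value of the three, though all three sit within the scatter of one another, so no order among them is claimed. Going by the values given here, the one step between measured neighbours, a 1.3-fold higher number from compound 1 to compound 2 (0.12 log units; within the scatter), lies within the scatter.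

Compound 4 `O=C(CSc1nnc(-c2ccncc2)n1-c1ccccc1)N/N=C/c1cc(Br)cc(Br)c1O` differs from compound 3 in one place: 3,5-dibromo-2-hydroxyphenyl in place of 4-nitrophenyl on a carbon with a double bond to nitrogen. Among the compounds with values here, no measured step touches the group on the carbon with a double bond to nitrogen; the only measured step concerns a different part of the molecule and was itself within the scatter. Nothing in the three numbers therefore points to a change beyond the scatter in this assay, and the expectation for compound 4 is a number close to that of compound 3, a 1.0-fold lower number from compound 3 to compound 4 (0.01 log units; within the scatter). The estimate for compound 4 in this assay is 10000 nM, with a range from 3000 nM to 33000 nM.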

Compound 4, half-maximal inhibitory concentration: 4500 nM
Beside the measured number, compound 4's estimate is 2.2-fold (0.35 log units) above it; low and high end bracket the measured number.
By their numbers in this assay, from the lowest: compounds 4, 1, 3 and 2 (each within the scatter of the next, the first and the last beyond it).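

In this assay, going by these compounds alone, the group on a carbon with a double bond to nitrogen is the first place where a change goes beyond the scatter: 3,5-dibromo-2-hydroxyphenyl in place of 4-nitrophenyl gives a 2.3-fold lower number from compound 3 to compound 4 (0.36 log units; beyond the scatter), a modest step. The two groups hold the same count of heavy atoms, so that count does not separate them, while the entering group brings a hydrogen-bond donor that the leaving group lacks. No supporting data bear on what lies behind this step.

The change removes the nitro group and adds the hydroxyl and both bromines at once, so the step cannot be assigned to any one of them. On these data alone, how a phenyl ring bearing an amine or a carboxylic acid would read at this place remains open.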